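Bromo on the shared core of a hydroxamic acid series

The source may hold more compounds than are shown below. What is called first, only, known or untested is meant among the compounds shown, and "the series" means these compounds.

Compound 1 `O=C(CCCCCCN1C(=O)/C(=N\O)c2ccccc21)NO` and compound 2 `CO/N=C1/C(=O)N(CCCCCCC(=O)NO)c2ccccc21` share a core and differ only in a group on its oxime. In a functional assay on ASPC1 cells (Homo sapiens) for antiproliferative activity, read by sulforhodamine B assay, with a stated time of 48 h (a higher number here means a weaker inhibitor, a lower number a stronger inhibitor), compound 1 gives 1100 nM, and in this assay compound 2 gives 1220 nM; the two numbers lie within the usual scatter of each other, so neither stands apart. Compound 3 `CO/N=C1/C(=O)N(CCCCCCC(=O)NO)c2ccc(Br)cc21` is not yet measured; it differs from compound 2 by bromo in place of hydrogen on an aromatic carbon. Among the measured compounds shown here, no measured pair shows a step of this kind, so no step beyond the scatter is expected in this assay, in either direction. The expected step of a 1.3-fold lower number from compound 2 to compound 3 (0.11 log units; within the scatter) is small, and compound 3 is estimated at 950 nM, between 400 nM and 2400 nM.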

Compound 3, half-maximal inhibitory concentration: 1680 nM
The estimate for compound 3 lay 1.8-fold (0.25 log units) below the measured number; measured number inside the range.
By their numbers in this assay, from the lowest: compounds 1, 2 and 3 (each within the scatter of the next).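

Bromo in place of hydrogen on an aromatic carbon is the first change on the aromatic ring of the shared core to be read, and in this assay it gives a 1.4-fold higher number from compound 2 to compound 3 (0.14 log units; within the scatter) and that step lies within the scatter. Among the compounds shown here, this carbon therefore accepts a bromine atom with no step that stands apart in this assay. No measurement at hand bears on why the number falls where it does. From the compounds shown here alone, whether an amine or a carboxylic acid on this same carbon would give a step beyond the scatter remains open, and so does whether bromo would give the same small step on compound 1.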